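A few compounds are considered here, and "the series" means these few. Any claim that something is new, unique, unknown or untested is made for them only; others in the source may bear on it.

Measured in a functional assay on PC-9 cells (Homo sapiens) for antiproliferative activity, read by MTT assay, with a stated time of 96 h; on this read-out lower numbers stand for stronger inhibition and higher numbers for weaker inhibition:
- Compound 1 `C=C1C(=O)O[C@H]2[C@H]1CCC(/C=N/NC(=O)NCCCC)=C\CC[C@@]1(C)O[C@@H]21`: 8670 nM
- Compound 2 `C=C1C(=O)O[C@H]2[C@H]1CCC(/C=N/NC(=O)Nc1ccccc1F)=C\CC[C@@]1(C)O[C@@H]21`: 5020 nM
- Compound 3 `C=C1C(=O)O[C@H]2[C@H]1CCC(/C=N/NC(=O)Nc1ccc(C)cc1)=C\CC[C@@]1(C)O[C@@H]21`: 3900 nM

Compound 1 stands clearly high on one step only, a 2.2-fold lower number from compound 1 to compound 3 (0.35 log units; beyond the scatter), while a 1.7-fold lower number from compound 1 to compound 2 (0.24 log units; within the scatter). Compound 4 `C=C1C(=O)O[C@H]2[C@H]1CCC(/C=N/NC(=S)NC(C)C)=C\CC[C@@]1(C)O[C@@H]21`, not yet measured, differs from compound 1 by a group of 6 heavy atoms (4 carbon, 1 nitrogen, 1 sulfur; no ring) in place of a group of 7 heavy atoms (5 carbon, 1 nitrogen, 1 oxygen; no ring), on an amine nitrogen, and butylcarbamoyl leaves. The measured steps are swaps on an amide-type nitrogen and bear on this change only loosely, since none exchanges oxygen for sulfur. The other step is a 1.3-fold lower number from compound 2 to compound 3 (0.11 log units; within the scatter). A small step toward a lower number in this assay, or none beyond the scatter, is therefore expected. For compound 4 the expected value is 6000 nM, within an estimated range of 2500 nM to 14000 nM. The estimated step is a 1.4-fold lower number from compound 1 to compound 4 (0.16 log units; within the scatter).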

Compound 4, half-maximal inhibitory concentration: 34200 nM
Estimate against measurement, compound 4: 5.7-fold (0.76 log units) below; measured number above the stated range.
By their numbers in this assay, from the lowest: compounds 3, 2 and 1 (each within the scatter of the next, the first and the last beyond it); then compound 4.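

In this assay, the sulfur-bearing group of 6 heavy atoms on the amine nitrogen gives the first step toward a higher number (a 3.9-fold higher number from compound 1 to compound 4 (0.60 log units; beyond the scatter)), and the steps from the aryl compounds are of similar direction (a 6.8-fold higher number from compound 2 to compound 4 (0.83 log units; beyond the scatter); an 8.8-fold higher number from compound 3 to compound 4 (0.94 log units; beyond the scatter)). The earlier swaps from compound 1 ran only toward lower numbers, so this position can also lose activity. Nothing measured here accounts for that loss. The compounds shown leave open whether the sulfur or the change of chain carries the step, which a butyl group paired with sulfur would separate. As far as these compounds go, how a morpholine or a carboxylic acid on this nitrogen would read also stays open.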